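Cytotoxicity notes: hydroxy removal at the benzylic carbon

The source may hold more compounds than are shown below. What is called first, only, known or untested is meant among the compounds shown, and "the series" means these compounds.

Measured compounds in an ADME assay on Raji cells (Homo sapiens) for cytotoxicity, read by CellTiter-Glo and resazurin assay, with a stated time of 72 h; a higher number here means that more compound is needed for the effect, a lower number that less compound is needed:
Compound 1 `CCOC(=O)CCCCCOc1ccc(CNC(C)C)cc1` gives > 26000 nM, a limit of the assay.
Compound 2 `CCCNCc1ccc(OCCCCCC(=O)OCC)cc1` gives > 26000 nM, a limit of the assay.
Compound 3 `CCOC(=O)CCCCCOc1ccc(C(O)O)cc1` gives > 27100 nM, a limit of the assay.

Compound 3 stands only at a limit; the two other values shown are limits as well (the limit of > 26000 nM in this assay, at which 2 of the 3 values shown sit, (the limit of > 27100 nM in this assay, at which 1 of the 3 values shown sits)). The steps a step that the two limits leave unreadable from compound 1 to compound 2, a step that the two limits leave unreadable from compound 1 to compound 3 and a step that the two limits leave unreadable from compound 2 to compound 3 are therefore unreadable in size. Compound 4 `CCOC(=O)CCCCCOc1ccc(CO)cc1` differs from compound 3 by hydrogen in place of hydroxy on a saturated chain carbon bound to an aromatic carbon and an oxygen on a saturated carbon. With every measured step unreadable, the expected step that the limit leaves unreadable from compound 3 to compound 4 in this assay cannot be anchored to a measured change and is expected to stay within the scatter, most likely again ending at a limit. Compound 4 is estimated at 30000 nM, range 12000 nM to 80000 nM.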

Compound 4, half-maximal effective concentration: > 27100 nM
Compound 4 ended at the assay's limit; the forecaster's own chance of this, stated with the estimate: 80%; the middle value does not contradict the limit.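

Compound 1, compound 2, compound 3 and compound 4 all stand at limits of the assay, so no new step can be read. The compounds shown leave open what concentration of any of them produces cytotoxicity.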